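A few compounds are considered here, and "the series" means these few. Any claim that something is new, unique, unknown or untested is made for them only; others in the source may bear on it.

Working notes on the series. In a functional assay on DLD-1 cells (Homo sapiens) for cytotoxicity, read by MTT assay, with a stated time of 48 h (a lower number here means a stronger inhibitor, a higher number a weaker inhibitor), compound 1 `Cc1ccc(-c2cn(/N=C/c3cc4ccccc4nc3Cl)c(N)n2)cc1` gives only a limit, > 50000 nM. Compound 2 `Cc1ccc(-c2cn(/N=C/c3cc4cc(C)ccc4nc3Cl)c(N)n2)cc1` gives 25200 nM in this assay, and compound 3 `Cc1ccc2nc(Cl)c(/C=N/n3cc(-c4ccc5ccccc5c4)nc3N)cc2c1` gives 10200 nM. Compound 1 sits at the limit of > 50000 nM in this assay, at which 1 of the 3 values shown sits. Compound 4 `Nc1nc(-c2cccs2)cn1/N=C/c1cc2ccccc2nc1Cl` differs from compound 1 by thiophen-2-yl in place of 4-methylphenyl on an aromatic carbon. Going by the values given here, two measured steps bear on this: an at least 1.9-fold lower number from compound 1 to compound 2 (0.29 log units; that floor lies within the scatter), and a 2.5-fold lower number from compound 2 to compound 3 (0.39 log units; beyond the scatter). The second step concerns the same aromatic carbon, with a larger aryl entering; here a smaller one enters, so no step beyond the scatter is expected in this assay, and a reported limit remains likely. For compound 4 the expected value is 60000 nM, range 20000 nM to 200000 nM, a change of a step that the limit leaves unreadable from compound 1 to compound 4.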

Compound 4, half-maximal inhibitory concentration: 10300 nM
The estimate for compound 4 lay 5.8-fold (0.77 log units) above the measured number, and the stated range ends above it.
By their numbers in this assay, from the lowest: compounds 3 and 4 (each within the scatter of the next); then compound 2. At a limit, above all of these: compound 1.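

Working from the shared core, thiophen-2-yl in place of 4-methylphenyl on this aromatic carbon gives an at least 4.8-fold lower number from compound 1 to compound 4 (0.68 log units; beyond the scatter) in this assay. A lower number at this position therefore does not require a larger aryl, since thiophen-2-yl has fewer heavy atoms than the group it replaces. Compound 1 gives only a limit, so the full size of this step cannot be read: the limit of > 50000 nM in this assay, at which 1 of the 4 values shown sits.

Still open, going by these compounds, is how phenyl or furan-2-yl on this carbon would compare, which would separate ring size from the sulfur. On these data alone, the effect of an amine or a carboxylic acid on the aryl ring is also open.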